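Dropping the methoxy: what compound 4 might show

This account rests on a few compounds, and the source may have more. Where it says the series, first, only, none or still open, it means among the compounds named here.

Measured compounds in a functional assay on MCF7 cells (Homo sapiens) for antiproliferative activity, read by MTT assay, with a stated time of 72 h; a higher number here means a weaker inhibitor, a lower number a stronger inhibitor:
compound 1 `CCN1CCN(c2cc(C)c3cc(NC(=O)c4ccccc4C)ccc3n2)CC1`: 10900 nM
compound 2 `CCN1CCN(c2cc(C)c3cc(NC(=O)c4cccc(Br)c4)ccc3n2)CC1`: 11600 nM
compound 3 `CCN1CCN(c2cc(C)c3cc(NC(=O)c4ccccc4OC)ccc3n2)CC1`: 13200 nM

Compound 3 gives the highest of the three numbers, but its separation from the others is small: the step of a 1.1-fold higher number from compound 2 to compound 3 (0.06 log units; within the scatter) and the step of a 1.2-fold higher number from compound 1 to compound 3 (0.08 log units; within the scatter) both lie within the scatter, so the three compounds cannot be ranked against one another. The three amide substituents therefore read as one undifferentiated group so far.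

Compound 4 `CCN1CCN(c2cc(C)c3cc(NC(=O)c4ccccc4)ccc3n2)CC1` is the next member. Its difference from compound 3 is hydrogen in place of methoxy on an aromatic carbon.

For the measured compounds named here, the steps that bear on this change are those already seen on the same part of the molecule. The step of a 1.2-fold higher number from compound 1 to compound 3 (0.08 log units; within the scatter) swaps methyl for methoxy at the same aromatic carbon and stays within the scatter; the steps of a 1.1-fold higher number from compound 1 to compound 2 (0.03 log units; within the scatter) and a 1.1-fold higher number from compound 2 to compound 3 (0.06 log units; within the scatter), which move or alter the substituent on the phenyl ring of the amide, likewise stay within the scatter. Going by the values given here, nothing among the measured compounds suggests that removing the methoxy altogether should move the number beyond the scatter. The expected step is therefore a 1.1-fold lower number from compound 3 to compound 4 (0.04 log units; within the scatter), with no direction claimed.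

Compound 4 is thus estimated at 12000 nM in this assay, with a range from 6000 nM to 24000 nM.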

Compound 4, half-maximal inhibitory concentration: 14200 nM
For compound 4 the middle estimate is 1.2-fold (0.07 log units) below the measured one, and the stated range covers the measured number.
By their numbers in this assay, from the lowest: compounds 1, 2, 3 and 4 (each within the scatter of the next).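

In this assay, the benzoyl amide with no substituent on its phenyl ring cannot be told apart from any of the substituted amides: hydrogen in place of methoxy (a 1.1-fold higher number from compound 3 to compound 4 (0.03 log units; within the scatter)), of bromo (a 1.2-fold higher number from compound 2 to compound 4 (0.09 log units; within the scatter)) and of methyl (a 1.3-fold higher number from compound 1 to compound 4 (0.11 log units; within the scatter)) all stay within the scatter. The earlier compounds shown here compared substituents only with one another, whereas these steps set each of them against the bare phenyl ring, and none of the three groups gives a readable difference from hydrogen. No supporting measurement bears on why the four numbers lie so close together.

Whether an amine or a carboxylic acid on the phenyl ring of the amide would give a step beyond the scatter remains open, as the methyl, methoxy and bromo groups shown cover only a few kinds of substituent. Also open, as far as these compounds go, is whether replacing the amide phenyl ring itself, or altering the shared core on which all four compounds agree, would separate any compound from this group.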